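This account rests on a few compounds, and the source may have more. Where it says the series, first, only, none or still open, it means among the compounds named here.

In an ADME assay on a cell-free system (plasma, Rattus norvegicus) for protein binding (on this read-out higher numbers stand for a larger free fraction and lower numbers for a smaller free fraction), compound 1 (`Cc1c(Cl)nnc2sc(C(=O)NC3CN(c4cc(C(F)(F)F)ncc4Cl)C3)c(N)c12`) gives 0.019, compound 2 (`COc1nnc2sc(C(=O)NC3CN(c4ncc(C(F)(F)F)cn4)C3)c(N)c2c1C`) gives 0.018 and compound 3 (`Cc1nnc2sc(C(=O)NC3CN(c4ncc(C(F)(F)F)cn4)C3)c(N)c2c1C`) gives 0.028. Compound 1 thus sits second of the three numbers, but all three lie within the scatter of one another, so the set shows no real spread.

Compound 4 (`COc1cc(N2CC(NC(=O)c3sc4nnc(Cl)c(C)c4c3N)C2)c(Cl)cn1`) keeps the core of compound 1 and makes one change: methoxy in place of trifluoromethyl on an aromatic carbon, (methoxy in place of trifluoromethyl on an aromatic carbon). Among the measured compounds shown here, no measured step removes trifluoromethyl, so the evidence is thin. For the measured compounds named here, the closest guide is the one measured step involving methoxy, a 1.6-fold higher number from compound 2 to compound 3 (0.19 log units; within the scatter), although that swap lies elsewhere in the molecule and exchanges methoxy for methyl. It gives no sign that methoxy moves this number much.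

The expected change is therefore small, an estimated 1.3-fold higher number from compound 1 to compound 4 (0.10 log units; within the scatter), which would not stand beyond the scatter. For compound 4 the expected value is 0.024, with an estimated range from 0.012 to 0.048.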

Compound 4, unbound fraction: 0.005
For compound 4 the middle estimate is 4.8-fold (0.68 log units) above the measured one; measured number outside the range, below it.
By their numbers in this assay, from the lowest: compound 4; then compounds 2, 1 and 3 (each within the scatter of the next).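

In this assay, among the compounds shown here, putting methoxy in place of trifluoromethyl on this aromatic carbon, next to the ring nitrogen, gives a 3.8-fold lower number from compound 1 to compound 4 (0.58 log units; beyond the scatter) and is the first step in this set to lie beyond the scatter. For the compounds shown here, the one earlier step, methyl in place of methoxy elsewhere in the molecule, was a 1.6-fold higher number from compound 2 to compound 3 (0.19 log units; within the scatter) and said nothing about this position, whereas the group on this carbon now proves able to shift the free fraction. No measurement shown here offers a reason for this drop.

As far as these compounds go, it remains open whether an amine or an ethoxy group on this same carbon would lower the number as methoxy does. This is also a single pair, so it cannot tell whether the same swap would act alike on a different core.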